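The source may hold more compounds than are shown below. What is called first, only, known or untested is meant among the compounds shown, and "the series" means these compounds.

Measured so far:
compound 1, `COc1cc(-c2nnc(SCc3ccc([N+](=O)[O-])cc3)o2)ccc1O`: 688000 nM
compound 2, `COc1cc(-c2nnc(SCc3ccccc3[N+](=O)[O-])o2)ccc1O`: 331000 nM

Both compounds have been run in an ADME assay on cells (Mus musculus, strain BALB/c) for cytotoxicity, read by MTT assay, with a stated time of 24 h; a lower number here means that less compound is tolerated, a higher number that more compound is tolerated. Going by the values given here, compound 1 holds the higher of the two numbers, and compound 2, the only other measured compound, sits a step below it that lies beyond the scatter of the method. Among the compounds with values here, no step between these two has been computed, since they differ in more than one place, so their two values stand on their own without a structural reading attached.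

Compound 3, `COc1cc(-c2nnc(SCc3ccc(Cl)cc3)o2)ccc1O`, is not yet measured in this assay. Relative to compound 1 the change is chloro in place of nitro on an aromatic carbon. Within the data shown here, no measured pair isolates this change, so any expectation rests on the level of compound 1 at 688000 nM together with the usual spread of the method. The working expectation is a step of modest size, within or close to the scatter, with no clear reason to favour either direction. The step expected is a 1.3-fold lower number from compound 1 to compound 3 (0.10 log units; within the scatter). Compound 3 is estimated at 550000 nM, with a range from 220000 nM to 1300000 nM.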

Compound 3, half-maximal cytotoxic concentration: 480000 nM
Estimate against measurement, compound 3: 1.1-fold (0.06 log units) above, and the stated range covers the measured number.
By their numbers in this assay, from the lowest: compounds 2, 3 and 1 (each within the scatter of the next, the first and the last beyond it).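

In this assay, the position on the six-membered aromatic ring of carbon only, para to a large group, now has its first comparison that differs in one place: chloro in place of nitro gives a 1.4-fold lower number from compound 1 to compound 3 (0.16 log units; within the scatter) on an otherwise unchanged structure. At this position, the nitro group, with 3 heavy atoms and 2 hydrogen-bond acceptors, and chloro, with 1 heavy atom and 0 hydrogen-bond acceptors, therefore give numbers that the method does not separate, although this rests on a single pair. No measurement at hand explains this result or ties it to either group.

The compounds shown leave open how an amine, a carboxylic acid or a longer chain would read at this position, since nitro and chloro both carry 0 hydrogen-bond donors and neither adds a ring. Also open, going by these compounds, is whether chloro in place of nitro would give a step of similar size in the setting of compound 2, where the nitro group stands elsewhere on the same ring.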